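A few compounds are considered here, and "the series" means these few. Any claim that something is new, unique, unknown or untested is made for them only; others in the source may bear on it.

Working notes on the series. Two members have been run in an ADME assay on microsomes from liver (Homo sapiens) for metabolic stability, with a stated time of 0.5 h, tested at 0.5 mg/mL (on this read-out higher numbers stand for a more stable compound and lower numbers for a less stable compound), so far. Compound 1 `CC(=O)N1CC(CNC(=O)c2cc(-c3ccccc3)no2)C1` carries a phenyl on the shared core, and in this assay compound 1 gives 50%. Compound 2 `CN(C)C(=O)CCNC(=O)c1cc(C2CCCCC2)no1` carries a cyclohexyl at the same place of the core and a different amide side. For compound 2 this assay reports only a limit, > 100%. That reading is the limit of > 100% in this assay, at which 1 of the 2 values shown sits, so for compound 2 there is no number, only the statement that the remaining fraction is not resolved beyond the limit.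

The next member is compound 3 `CN(C)C(=O)CCNC(=O)c1cc(-c2ccccc2)no1`. It keeps the amide side of compound 2, and the change is phenyl in place of cyclohexyl on an aromatic carbon. Within the data shown here, no step between two measured compounds covers this exchange, and the pair of compound 1 and compound 3 differs in two places, so it gives no step either.

The expectation for compound 3 is a fall from the limit of compound 2, by a number at least 25 percentage points lower from compound 2 to compound 3 (beyond the scatter), beyond the scatter. Compound 3 is estimated at 75%, with a range from 45% to 100%.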

Compound 3, percent of the compound remaining: 81%
Compound 3: middle estimate off by 6 percentage points, on the low side; low and high end bracket the measured number.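

With the amide side of compound 2 held, the exchange of cyclohexyl for phenyl on an aromatic carbon of the five-membered aromatic ring gives, in this assay, a number at least 19 percentage points lower from compound 2 to compound 3 (beyond the scatter). Compound 2 carries a limit and not a number, so this step has a bound but no exact size: the limit of > 100% in this assay, at which 1 of the 3 values shown sits.

With phenyl held on the shared core, the amide side also moves the reading, with a number 31 percentage points higher from compound 1 to compound 3 (beyond the scatter), so the group at this aromatic carbon does not settle the result in this assay on its own.

The compounds shown leave open whether the exchange of cyclohexyl for phenyl gives a step of similar direction when the amide side carries the 1-acetylazetidin-3-yl group of compound 1. They also leave open how other groups at this aromatic carbon, such as cyclopentyl, tert-butyl or a pyridine ring, would read in this assay, and how an amine or a carboxylic acid in place of the dimethylcarbamoyl end of the chain would read.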